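Pyrrolidine thioamide in place of N-methyl thioamide

The source may hold more compounds than are shown below. What is called first, only, known or untested is meant among the compounds shown, and "the series" means these compounds.

Measured so far:
compound 1 `C/N=C(\S)CCn1nc(-c2ccccc2)ccc1=O` — 58.5 mg/kg
compound 2 `N=C(S)CCN1N=C(c2cccs2)CCC1=O` — 77.3 mg/kg
compound 3 `C/N=C(\S)CCn1ncccc1=O` — a limit, > 100 mg/kg

In a functional assay on the whole organism (stomach) with Rattus norvegicus as the target (on this read-out higher numbers stand for an effect only at larger amounts of compound and lower numbers for an effect already at smaller amounts), compound 1 gives 58.5 mg/kg. Compound 2, with a different core and no methyl on the thioamide nitrogen, gives 77.3 mg/kg, which sits within the scatter of compound 1. For compound 3 this assay reports only a limit, > 100 mg/kg. Within the data shown here, the one step measured here is the removal of the phenyl from the aromatic carbon, an at least 1.7-fold higher number from compound 1 to compound 3 (0.23 log units; that floor lies within the scatter), and it rests on (the limit of > 100 mg/kg in this assay, at which 1 of the 3 values shown sits).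

The step from compound 1 to compound 4 `O=c1ccc(-c2ccccc2)nn1CCC(=S)N1CCCC1` is of another kind: a group of 7 heavy atoms (5 carbon, 1 nitrogen, 1 sulfur; one five-membered non-aromatic ring with 1 hetero atom) in place of a group of 4 heavy atoms (2 carbon, 1 nitrogen, 1 sulfur; no ring), on a saturated chain carbon, two bonds along the chain from an aromatic nitrogen. Among the measured compounds shown here, none of the measured steps touches this part of the molecule; compounds 1 and 2 differ there by a methyl but also in their core, so their pair gives no clean reading. The only firm observation is that the two compounds carrying a phenyl or thienyl on the core both give numbers rather than limits.

Compound 4 keeps the phenyl-bearing core of compound 1, so its expected step is a 1.0-fold higher number from compound 1 to compound 4 (0.01 log units; within the scatter), no larger than the scatter in either direction. The estimate for compound 4 in this assay is therefore 60 mg/kg, with a range from 25 mg/kg to 140 mg/kg.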

Compound 4, dose for half-maximal effect: > 100 mg/kg
Compound 4: a limit, no number; the forecaster's own chance of this, stated with the estimate: 20%; middle value at least 1.6-fold (0.22 log units) away from the limit.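

Among these compounds, this is the first reading of a change at this end of the chain, on a saturated chain carbon, two bonds along the chain from an aromatic nitrogen: in this assay compound 4, with the pyrrolidine thioamide, gives > 100 mg/kg, which is a limit and not a number. The step is an at least 1.7-fold higher number from compound 1 to compound 4 (0.23 log units; that floor lies within the scatter), so it has a floor but no fixed size, and it cannot be placed beyond the scatter. With the phenyl-bearing core kept, a phenyl or thienyl on the core no longer goes with a number rather than a limit, compound 4 being the one that goes against this, and the limit also caps what can be read here: the limit of > 100 mg/kg in this assay, at which 2 of the 4 values shown sit.

The compounds shown leave open whether the five-membered non-aromatic ring itself matters or the change from 1 hydrogen-bond donor to 0 hydrogen-bond donors, and a thioamide with two methyl groups on its nitrogen and no ring would separate the two. They also leave open how far compound 4 lies from compound 1, and whether a piperidine ring on the thioamide nitrogen would give a number rather than a limit.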